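A few compounds are considered here, and "the series" means these few. Any claim that something is new, unique, unknown or untested is made for them only; others in the source may bear on it.

Measured so far, in a functional assay on MDA-MB-231 cells (Homo sapiens) for antiproliferative activity, read by MTT assay, with a stated time of 48 h; on this read-out lower numbers stand for stronger inhibition and higher numbers for weaker inhibition:
compound 1 `Cc1ccc2nc(Nc3nc(Nc4ccc(S(N)(=O)=O)cc4)ncc3F)sc2c1` gives 6390 nM
compound 2 `NS(=O)(=O)c1ccc(Nc2ncc(F)c(Nc3nc4ccccc4s3)n2)cc1` gives 22600 nM
compound 3 `CS(=O)(=O)c1ccc(Nc2nccc(Nc3nc4ccccc4s3)n2)cc1` gives 5910 nM

Compound 4 `Cc1ccc2nc(Nc3ccnc(Nc4ccc(S(C)(=O)=O)cc4)n3)sc2c1` has not yet been measured. It is built from compound 3 by a single change, (methyl in place of hydrogen on an aromatic carbon). The same change has been made once before among these compounds: going from compound 2 to compound 1, (methyl in place of hydrogen on an aromatic carbon), it gave a 3.5-fold lower number from compound 2 to compound 1 (0.55 log units; beyond the scatter). How the core of compound 3 differs from the core of compound 2 is not broken down here; their values show compound 3 with the lower number, while compound 3 and compound 1 lie within the scatter of each other. Because the earlier step of a 3.5-fold lower number from compound 2 to compound 1 (0.55 log units; beyond the scatter) was modest, the step from compound 3 to compound 4 is expected to run in the same direction at a similar or somewhat smaller size, a 2.4-fold lower number from compound 3 to compound 4 (0.37 log units; beyond the scatter). Compound 4 is therefore estimated at 2500 nM, likely between 1000 nM and 7000 nM.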

Compound 4, half-maximal inhibitory concentration: 4440 nM
Estimate against measurement, compound 4: 1.8-fold (0.25 log units) below; low and high end bracket the measured number.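

In this assay, the methyl on the core of compound 3 gives a 1.3-fold lower number from compound 3 to compound 4 (0.12 log units; within the scatter), so on this core the change does not clearly move the number. Going by these compounds alone, with only two pairs, this cannot prove that the methyl acts equally on both cores, although it gives no sign that the effect depends on the core. Set side by side, the two steps cannot be told apart: the same change on two cores in this assay, a 3.5-fold lower number (0.55 log units; beyond the scatter) from compound 2 to compound 1 and a 1.3-fold lower number (0.12 log units; within the scatter) from compound 3 to compound 4, 2.7-fold (0.42 log units) apart, within the scatter of two such steps

The compounds shown leave open whether a chlorine atom, a methoxy group or a longer chain such as ethyl on that same aromatic carbon would shift the number further than methyl. They also leave open whether the step would hold on a third core.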